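Hydrazone-bearing thiazoles: swapping the acyl aryl group

A few compounds are considered here, and "the series" means these few. Any claim that something is new, unique, unknown or untested is made for them only; others in the source may bear on it.

Of the compounds shown here, three built on one shared core have been tested in a functional assay on MCF7 cells (Homo sapiens) for inhibition, read by MTT assay, with a stated time of 72 h; a higher number here means a weaker inhibitor, a lower number a stronger inhibitor. Compound 1 `CN(C(=O)NC(=O)c1cccc(C(F)(F)F)c1)c1nc(C(F)(F)F)c(C(=O)N/N=C/c2ccccc2C(F)(F)F)s1` gives 7.69 ug/mL. Compound 2 `CN(C(=O)NC(=O)c1ccc(C(F)(F)F)cc1)c1nc(C(F)(F)F)c(C(=O)N/N=C/c2cccc(C(F)(F)F)c2)s1` gives 8.95 ug/mL. Compound 3 `CN(C(=O)NC(=O)c1c(Cl)cccc1Cl)c1nc(C(F)(F)F)c(C(=O)N/N=C/c2ccccc2C(F)(F)F)s1` gives 6.24 ug/mL; its number sits within the scatter of both of the others, so no order among the three can be claimed. For the measured compounds named here, the only single-point comparison among them, a 1.2-fold lower number from compound 1 to compound 3 (0.09 log units; within the scatter), shows how little the acyl aryl group has moved the read-out so far.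

Compound 4 `CN(C(=O)NC(=O)c1ccc(C(F)(F)F)cc1)c1nc(C(F)(F)F)c(C(=O)N/N=C/c2ccccc2C(F)(F)F)s1` is not yet measured. It differs from compound 3 by 4-(trifluoromethyl)phenyl in place of 2,6-dichlorophenyl on a carbonyl carbon. Compound 2 carries the same 4-(trifluoromethyl)phenyl group but also a different hydrazone aryl, so its value can only be set beside compound 3 as two numbers within the scatter. Given that the step from compound 1 to compound 3 stayed within the scatter, the step of a 1.2-fold higher number from compound 3 to compound 4 (0.08 log units; within the scatter) is expected to do the same. For compound 4 the estimated value in this assay is 7.5 ug/mL, with a range from 4.5 ug/mL to 12.5 ug/mL.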

Compound 4, half-maximal inhibitory concentration: 2.21 ug/mL
Estimate against measurement, compound 4: 3.4-fold (0.53 log units) above; the whole stated range lies above it.
By their numbers in this assay, from the lowest: compound 4; then compounds 3, 1 and 2 (each within the scatter of the next).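

In this assay the acyl aryl group is no longer silent: there is a 2.8-fold lower number from compound 3 to compound 4 (0.45 log units; beyond the scatter) with 4-(trifluoromethyl)phenyl in place of 2,6-dichlorophenyl on a carbonyl carbon, and a 3.5-fold lower number from compound 1 to compound 4 (0.54 log units; beyond the scatter) with 4-(trifluoromethyl)phenyl in place of 3-(trifluoromethyl)phenyl, so the choice of aryl group on this carbonyl carbon can matter, which the earlier step did not show. The hydrazone aryl matters too, with a 4.0-fold lower number from compound 2 to compound 4 (0.61 log units; beyond the scatter) when 2-(trifluoromethyl)phenyl replaces 3-(trifluoromethyl)phenyl on a carbon with a double bond to nitrogen. Nothing measured here accounts for these shifts.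

As far as these compounds go, only compounds 2 and 4 carry 4-(trifluoromethyl)phenyl on the carbonyl carbon, so how it behaves with other hydrazone aryl groups remains open. Also open, from the compounds shown here alone, is what an amine or a carboxylic acid would do in place of the trifluoromethyl group on that ring.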